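A few compounds are considered here, and "the series" means these few. Any claim that something is new, unique, unknown or untested is made for them only; others in the source may bear on it.

Measured compounds:
compound 1 `CCCn1c(=O)c2nc(-c3cccs3)[nH]c2n(C)c1=O` gives 9.68 nM in an assay for displacement of a labelled ligand from adenosine receptor A1 (Rattus norvegicus); a higher number here means a weaker inhibitor, a lower number a stronger inhibitor;
compound 2 `CCCn1c(=O)c2nc(-c3ccsc3)[nH]c2n(C)c1=O` gives 6.4 nM in this assay;
compound 3 `CCCn1c(=O)c2nc(-c3cccnc3)[nH]c2n(CCC)c1=O` gives 11.6 nM in this assay.

Compound 3 stands at the highest of the three numbers, but its distance to compound 1 and to compound 2 is within the scatter, so the three cannot be ordered on these data. For the measured compounds named here, the one measured step, a 1.5-fold lower number from compound 1 to compound 2 (0.18 log units; within the scatter), concerns the aryl ring and not the chain, and it too lies within the scatter.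

Compound 4 `CCCn1c(=O)c2nc(-c3cccnc3)[nH]c2n(C)c1=O` arises from compound 3 by the change (hydrogen in place of ethyl on a saturated chain carbon bound to an aromatic nitrogen). Going by the values given here, no measured pair shows this change alone: compounds 1 and 2 carry the methyl chain and compound 3 the propyl chain, but they differ in the aryl ring as well. Since all three values sit within the scatter of one another, compound 4 is expected to stay in that same range, with a 1.2-fold lower number from compound 3 to compound 4 (0.06 log units; within the scatter) amounting to no step beyond the scatter. The estimate for compound 4 is 10 nM, between 4 nM and 25 nM.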

Compound 4, inhibition constant: 70.2 nM
Estimate against measurement, compound 4: 7.0-fold (0.85 log units) below; measured number outside the range, above it.
By their numbers in this assay, from the lowest: compounds 2, 1 and 3 (each within the scatter of the next); then compound 4.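

In this assay, for the compounds shown here, this position turns out not to be indifferent: with the pyridin-3-yl ring in place, going from propyl to methyl gives a 6.1-fold higher number from compound 3 to compound 4 (0.78 log units; beyond the scatter) and is the first single change here to pass beyond the scatter. The aryl ring also counts once the methyl chain is kept, where pyridin-3-yl in place of thiophen-3-yl gives an 11-fold higher number from compound 2 to compound 4 (1.04 log units; beyond the scatter) and pyridin-3-yl in place of thiophen-2-yl gives a 7.3-fold higher number from compound 1 to compound 4 (0.86 log units; beyond the scatter). The two thiophene compounds with the methyl chain therefore differ clearly from compound 4, although compound 3 stays within the scatter of both.

Nothing measured here explains these steps. From the compounds shown here alone, whether propyl in place of methyl would matter as much with either thiophene ring stays open, as does the effect of a longer chain such as butyl or a chain carrying an amine.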